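Working notes: from compound 3 to the unsubstituted benzamide

The compounds below may be only part of what the source reports. "The series", "measured", "known", "first", "only" and "open" are said of these compounds alone.

Measured so far in a functional assay on B16 cells (Mus musculus) for inhibition; on this read-out lower numbers stand for stronger inhibition and higher numbers for weaker inhibition
- compound 1 `COc1cc(/C=C/C(=O)c2cccc(NC(=O)c3cccs3)c2)ccc1O` at 6.93 ug/mL
- compound 2 `COc1cc(/C=C/C(=O)c2cccc(NC(=O)c3ccc(Cl)cc3)c2)ccc1O` at 0.59 ug/mL
- compound 3 `COc1cc(/C=C/C(=O)c2cccc(NC(=O)c3ccc(Cl)c(Cl)c3)c2)ccc1O` at 3.88 ug/mL

In this assay compound 3 keeps to the high side of the three numbers, as placed by a 1.8-fold lower number from compound 1 to compound 3 (0.25 log units; within the scatter) and a 6.6-fold higher number from compound 2 to compound 3 (0.82 log units; beyond the scatter) in this series.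

The change to compound 4 `COc1cc(/C=C/C(=O)c2cccc(NC(=O)c3ccccc3)c2)ccc1O` is phenyl in place of 3,4-dichlorophenyl on a carbonyl carbon.

The chloro step above covers only one of the two chlorines lost. Going by the values given here, the swing of a 12-fold lower number from compound 1 to compound 2 (1.07 log units; beyond the scatter) shows that the group on the carbonyl carbon can move the number widely, yet no measured compound carries plain phenyl. The expected outcome is a 1.3-fold lower number from compound 3 to compound 4 (0.11 log units; within the scatter) and so no clear step beyond the scatter. Compound 4 is thus estimated at 3 ug/mL with 0.8 ug/mL to 10 ug/mL as its expected range.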

Compound 4, half-maximal inhibitory concentration: 0.82 ug/mL
The estimate for compound 4 lay 3.7-fold (0.56 log units) above the measured number; low and high end bracket the measured number.
By their numbers in this assay, from the lowest: compounds 2 and 4 (each within the scatter of the next); then compounds 3 and 1 (each within the scatter of the next).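

In this assay plain phenyl and 4-chlorophenyl on this carbonyl carbon do not separate (a 1.4-fold higher number from compound 2 to compound 4 (0.14 log units; within the scatter)), while 3,4-dichlorophenyl stands apart from phenyl (a 4.7-fold lower number from compound 3 to compound 4 (0.68 log units; beyond the scatter)). Phenyl also stands clear of thiophen-2-yl (an 8.5-fold lower number from compound 1 to compound 4 (0.93 log units; beyond the scatter)), so a simple six-membered aromatic ring of carbon only, without chloro, is enough for a low number here. Nothing at hand accounts for these steps.

Open, from the compounds shown here alone, is whether an amine or a carboxylic acid on the phenyl ring would keep the number low. Also open, going by these compounds, is how a cyclohexyl group would read in place of phenyl on this carbonyl carbon.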